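The source may hold more compounds than are shown below. What is called first, only, known or untested is meant among the compounds shown, and "the series" means these compounds.

Compound 1 `Cc1cccc(NC(=O)N[C@@H](C)c2ccccc2)c1` and compound 2 `CCc1cccc(NC(=O)N[C@@H](C)c2ccccc2)c1` share one core and differ only by methyl in place of hydrogen on a saturated chain carbon bound to an aromatic carbon. In an ADME assay on the whole organism with Oryza sativa as the target, tested at 1 uM (a higher number here means a weaker effect of the compound at the concentration tested, a lower number a stronger effect), compound 1 gives 100%, and in this assay compound 2 gives 94%; the step between them is a number 6 percentage points lower from compound 1 to compound 2 (within the scatter). Compound 3 `CCCCCCc1ccc(NC(=O)N[C@H](C)c2ccccc2)cc1` carries a longer chain on a core of its own; the difference between the two cores of compound 1 and compound 3 is not broken down here. In this assay compound 3 gives 101%, a number that lies within the scatter of the values of both compound 1 and compound 2, so the three measured compounds cannot be told apart in this read-out.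

Compound 4 `CCCCCCCc1ccc(NC(=O)N[C@H](C)c2ccccc2)cc1` has not yet been measured and differs from compound 3 by methyl in place of hydrogen on a saturated chain carbon, six bonds along the chain from an aromatic carbon. For the measured compounds named here, this is the same kind of change as the one from compound 1 to compound 2, but not the same: in compound 2 the methyl enters on a saturated chain carbon bound to an aromatic carbon, whereas in compound 4 it enters on a saturated chain carbon, six bonds along the chain from an aromatic carbon. The expected step of a number 3 percentage points lower from compound 3 to compound 4 (within the scatter) is small, because the earlier step of a number 6 percentage points lower from compound 1 to compound 2 (within the scatter) stayed within the scatter and because compound 3 already gives 101%. Compound 4 is therefore expected to give 98% in this assay, most likely between 88% and 106%.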

Compound 4, a percentage reported as activity, at one concentration (the size of the read-out at that concentration, not a potency): 100%
Beside the measured number, compound 4's estimate is 2 percentage points below it; the measured number falls inside the stated range.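

In this assay the new step is a number 1 percentage points lower from compound 3 to compound 4 (within the scatter), and set beside the earlier step it shows no difference between the two cores: the same change on two cores in this assay, a number 6 percentage points lower (within the scatter) from compound 1 to compound 2 and a number 1 percentage points lower (within the scatter) from compound 3 to compound 4, 5 percentage points apart, within the scatter of two such steps. For these two pairs, then, methyl in place of hydrogen leaves the read-out within the scatter on both cores, once on a saturated chain carbon bound to an aromatic carbon and once on a saturated chain carbon, six bonds along the chain from an aromatic carbon. This does not show that the change has a shared effect that carries from one core to the other: neither step rises out of the scatter, the methyl enters at a different place in each pair, and two such small steps can agree without either of them being a real effect.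

The compounds shown leave open whether a group of another kind in place of the chain, such as an amine or a carboxylic acid, would move the number beyond the scatter. They also leave open whether a longer chain would do so, and how any of these compounds would read at another concentration.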